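The source may report more compounds than this note shows. Statements on the series, on what has been measured and on what is new or still open speak of the compounds shown alone.

Measured so far in an assay on isolated protein for inhibition of Amine oxidase [flavin-containing] A (Homo sapiens), read by fluorescence and Amplex Red, with a stated time of 30 min, tested at 1 nM; on this read-out higher numbers stand for a stronger effect at the one concentration tested and lower numbers for a weaker effect:

compound 1 `CCCNc1nnc(SCC(=O)N(Cc2cccc([N+](=O)[O-])c2)c2ccc(F)cc2)s1` gives 20.5%
compound 2 `CC(C)CNc1nnc(SCC(=O)N(Cc2cccc([N+](=O)[O-])c2)c2ccc(F)cc2)s1` gives 17.3%
compound 3 `COCCNc1nnc(SCC(=O)N(Cc2cccc([N+](=O)[O-])c2)c2ccc(F)cc2)s1` gives 26.9%

Compound 3 stands highest of the three numbers, but both gaps to the others lie within the scatter: a number 6.4 percentage points higher from compound 1 to compound 3 (within the scatter) and a number 9.6 percentage points higher from compound 2 to compound 3 (within the scatter). Compound 4 `CC(C)Nc1nnc(SCC(=O)N(Cc2cccc([N+](=O)[O-])c2)c2ccc(F)cc2)s1` differs from compound 3 in one place: isopropyl in place of 2-methoxyethyl on a nitrogen on an aromatic ring. Among the measured compounds shown here, two measured steps bear on this change. The step of a number 6.4 percentage points higher from compound 1 to compound 3 (within the scatter) brings a methoxy onto the saturated chain in place of methyl, and the step of a number 9.6 percentage points higher from compound 2 to compound 3 (within the scatter) exchanges isopropyl for methoxymethyl on the chain carbon bound to the ring nitrogen; each is a small gain, within the scatter. The change to compound 4 runs the other way, removing the methoxy and bringing in isopropyl, so a small downward step is expected for compound 4, not beyond the scatter: a number 7.9 percentage points lower from compound 3 to compound 4 (within the scatter). Compound 4 is therefore estimated at 19%, in the range 10% to 28%.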

Compound 4, a percentage reported as inhibition, at one concentration (the size of the read-out at that concentration, not a potency): 13.6%
Estimate against measurement, compound 4: 5.4 percentage points above; the range from low to high includes it.
By their numbers in this assay, from the lowest: compounds 4, 2, 1 and 3 (each within the scatter of the next, the first and the last beyond it).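

Among the compounds shown here, at this nitrogen in this assay, isopropyl in place of 2-methoxyethyl gives the only step in the set beyond the scatter: a number 13.3 percentage points lower from compound 3 to compound 4 (beyond the scatter). The all-carbon chains are not separated from one another, with isopropyl in place of isobutyl at a number 3.7 percentage points lower from compound 2 to compound 4 (within the scatter) and isopropyl in place of propyl at a number 6.9 percentage points lower from compound 1 to compound 4 (within the scatter), so 2-methoxyethyl stands apart from isopropyl alone, not from propyl or isobutyl. No measured evidence accounts for this step.

Still open, as far as these compounds go, is whether a 2-hydroxyethyl group or a longer ether chain such as 3-methoxypropyl on this nitrogen would read with compound 3 or with the all-carbon chains. From the compounds shown here alone, a chain ending in an amine, such as 2-aminoethyl, is equally open.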